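The source may hold more compounds than are shown below. What is called first, only, known or untested is meant among the compounds shown, and "the series" means these compounds.

Compound 1, `O=S(=O)(/C=C/c1ccccc1)Nc1ccc(Cl)cc1`, gives 20000 nM in a functional assay on K562 cells (Homo sapiens) for cytotoxicity, read by trypan blue exclusion, with a stated time of 96 h; a higher number here means a weaker inhibitor, a lower number a stronger inhibitor.
Compound 2, `COc1cc(OC)c(/C=C/S(=O)(=O)Nc2ccc(OC)c(OP(=O)(O)O)c2)c(OC)c1`, gives 7.5 nM in this assay.

Compound 2 stands at the lowest of the two numbers, and compound 1 lies far above it, well beyond the scatter. Compound 3, `COC(=O)C(C)(C)Nc1cc(NS(=O)(=O)/C=C/c2c(OC)cc(OC)cc2OC)ccc1OC`, differs from compound 2 in one place: a group of 8 heavy atoms (5 carbon, 1 nitrogen, 2 oxygen; no ring) in place of a group of 5 heavy atoms (4 oxygen, 1 phosphorus; no ring), on an aromatic carbon. No change of this kind between two measured compounds is shown, so the expectation rests on compound 2 alone. The step is expected to raise the number moderately, a 4.0-fold higher number from compound 2 to compound 3 (0.60 log units; beyond the scatter). Compound 3 is therefore estimated at 30 nM, within a range from 5 nM to 300 nM.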

Compound 3, half-maximal inhibitory concentration: 300 nM
Compound 3: the middle estimate sits 10-fold (1.00 log units) below what was measured; low and high end bracket the measured number.
By their numbers in this assay, from the lowest: compound 2; then compound 3; then compound 1.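

Replacing the group of 4 oxygen and 1 phosphorus with (1-(methoxycarbonyl)-1-methylethyl)amino, ortho to a methoxy group, gives a 40-fold higher number from compound 2 to compound 3 (1.60 log units; beyond the scatter) in this assay and shows that the number depends strongly on what occupies this position. Even so, compound 3 gives 300 nM, so phosphorus is not required for a measurable effect here. Nothing measured explains the size of this step. Still open, on these data alone, is whether a simple amine here, or a carboxylic acid in place of the methyl ester, would bring the number closer to that of compound 2.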